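Removing a chloro group from a benzothiazolyl thioether amide

This account rests on a few compounds, and the source may have more. Where it says the series, first, only, none or still open, it means among the compounds named here.

Measured so far in a functional assay on DLD-1 cells (Homo sapiens) for cytotoxicity, read by resazurin assay, with a stated time of 48 h; on this read-out lower numbers stand for an effect already at smaller amounts and higher numbers for an effect only at larger amounts of compound:
- compound 1, `O=C(Nc1ccc(Sc2nc3ccccc3s2)cc1)c1cc(Br)cc(Br)c1O`, gives 20000 nM
- compound 2, `COc1c(Br)cccc1C(=O)Nc1ccc(Sc2nc3ccccc3s2)c(Cl)c1`, gives 10000 nM
- compound 3, `O=C(Nc1ccc(Sc2nc3ccccc3s2)c(Cl)c1)c1cccc(Br)c1O`, gives 22000 nM

Compound 3 has the highest number of the three. Going by the values given here, its gap to compound 1 is within the scatter, so the two are indistinguishable on this read-out; only compound 2 is clearly apart from it, and the single step in this set, a 2.2-fold higher number from compound 2 to compound 3 (0.34 log units; beyond the scatter), is a modest rise that comes from a change on the oxygen, not from the part of the shared core that is altered next.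

Compound 4, `O=C(Nc1ccc(Sc2nc3ccccc3s2)cc1)c1cccc(Br)c1O`, is compound 3 with one change: hydrogen in place of chloro on an aromatic carbon. Among the compounds with values here, no measured step isolates this chloro, since compound 1 differs from compound 3 in two places at once; all that can be said is that compound 1, lacking the chloro, sits within the scatter of compound 3. On that basis the expected step of a 1.1-fold lower number from compound 3 to compound 4 (0.04 log units; within the scatter) is none beyond the scatter. Compound 4 is therefore estimated at 20000 nM in this assay, with a likely range from 8000 nM to 50000 nM.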

Compound 4, half-maximal effective concentration: 12000 nM
For compound 4 the middle estimate is 1.7-fold (0.22 log units) above the measured one; the measured number falls inside the stated range.
By their numbers in this assay, from the lowest: compounds 2, 4, 1 and 3 (each within the scatter of the next, the first and the last beyond it).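

Hydrogen in place of chloro can now be read on its own at this aromatic carbon, which is ortho to a large group and meta to a large group: in this assay, the swap gives a 1.8-fold lower number from compound 3 to compound 4 (0.26 log units; within the scatter), so this chloro has no effect that can be told apart from the scatter of repeated measurements. Compound 4 also isolates a second single change, the loss of a bromo group, and in this assay that swap gives a 1.7-fold lower number from compound 1 to compound 4 (0.22 log units; within the scatter), so neither halogen shows a readable effect on its own. Nothing available explains why the values fall where they do.

The compounds shown compare only chloro and hydrogen at this carbon, so it remains open whether a different group there, such as an amine or a methoxy group, would move the number beyond the scatter. Going by these compounds alone, also open is whether a 2.2-fold higher number from compound 2 to compound 3 (0.34 log units; beyond the scatter), the one step here beyond the scatter, would hold on the core of compound 4, which has hydrogen in place of that chloro.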